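This account rests on a few compounds, and the source may have more. Where it says the series, first, only, none or still open, it means among the compounds named here.

Measured in a functional assay on MCF7 cells (Homo sapiens) for cytotoxicity, read by sulforhodamine B assay, with a stated time of 48 h; a higher number here means a weaker inhibitor, a lower number a stronger inhibitor:

- compound 1 `Cc1ccccc1OS(=O)(=O)c1cccc(NC(=O)NCCCCl)c1`: 27000 nM
- compound 2 `CCc1ccccc1OS(=O)(=O)c1cccc(NC(=O)NCCCCl)c1`: 25000 nM
- compound 3 `CCCc1ccccc1OS(=O)(=O)c1cccc(NC(=O)NCCCCl)c1`: 14000 nM

Compound 2 sits in a tight group: its value lies within the usual scatter of those of compound 1 and compound 3, so no order can be read among them. Compound 4 `CCNC(=O)Nc1cccc(S(=O)(=O)Oc2ccccc2CC)c1` has not yet been measured. It differs from compound 2 by hydrogen in place of chloromethyl on a saturated chain carbon, two bonds along the chain from an amide-type nitrogen. In words, this is hydrogen in place of chloromethyl on a saturated chain carbon, two bonds along the chain from an amide-type nitrogen, so 3-chloropropyl becomes ethyl.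

The measured steps, a 1.1-fold lower number from compound 1 to compound 2 (0.03 log units; within the scatter), a 1.8-fold lower number from compound 2 to compound 3 (0.25 log units; within the scatter) and a 1.9-fold lower number from compound 1 to compound 3 (0.29 log units; within the scatter), all lie within the scatter. However, they alter a different chain, the one bound to an aromatic carbon, so they give no direct guide here. Going by these compounds, the loss of the chlorine is untested in this set, so a modest move towards a weaker inhibitor is expected, with wide uncertainty. The expected change is a 1.6-fold higher number from compound 2 to compound 4 (0.20 log units; within the scatter). Compound 4 is estimated at 40000 nM, with an expected range of 15000 nM to 100000 nM.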

Compound 4, half-maximal inhibitory concentration: 31000 nM
Beside the measured number, compound 4's estimate is 1.3-fold (0.11 log units) above it; the range from low to high includes it.
By their numbers in this assay, from the lowest: compounds 3, 2, 1 and 4 (each within the scatter of the next, the first and the last beyond it).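

Every earlier step altered the chain bound to an aromatic carbon, whereas compound 4 alone alters the chain on the amide-type nitrogen. In this assay, exchanging 3-chloropropyl for ethyl gives a 1.2-fold higher number from compound 2 to compound 4 (0.09 log units; within the scatter), so in this pair the chlorine is not needed for a number of this size. Nothing available explains this result.

Going by these compounds, it remains open whether the same exchange would give a similar result on the core of compound 1 or compound 3, where the chain bound to an aromatic carbon differs. Also open, on these data alone, is how the number would respond to an amine, a carboxylic acid or a longer carbon chain in place of chloromethyl on this saturated chain carbon.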